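This account rests on a few compounds, and the source may have more. Where it says the series, first, only, none or still open, it means among the compounds named here.

The compounds measured:
Compound 1 `Cc1cc(C)c(S(=O)(=O)N2CCC(N3CCC(CCO)CC3)CC2)c(C)c1`: in an ADME assay on HCT-116 cells (Homo sapiens) for cytotoxicity, read by CellTiter-Glo, with a stated time of 72 h (a higher number here means a weaker inhibitor, a lower number a stronger inhibitor), compound 1 gives > 5000 nM, which is a limit of the assay.
Compound 2 `Cc1cc(C)c(S(=O)(=O)N2CCC(N3CCC(CCC#N)CC3)CC2)c(C)c1`: in this assay compound 2 gives > 5000 nM, a limit as well.
Compound 3 `Cc1cc(C)c(S(=O)(=O)N2CCC(N3CCC(Cc4ccc(F)cc4)CC3)CC2)c(C)c1`: in this assay compound 3 gives > 5000 nM, again a limit.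

Compound 1 therefore stands only at a limit, and the two further values shown are limits too: the limit of > 5000 nM in this assay, at which 3 of the 3 values shown sit. The steps a step that the two limits leave unreadable from compound 1 to compound 2, a step that the two limits leave unreadable from compound 1 to compound 3 and a step that the two limits leave unreadable from compound 2 to compound 3 are consequently left unreadable. Compound 4 `Cc1cc(C)c(S(=O)(=O)N2CCC(C(=O)N3CCC(C)CC3)CC2)c(C)c1` differs from compound 1 by (4-methylpiperidin-1-yl)carbonyl in place of 4-(2-hydroxyethyl)piperidin-1-yl on a saturated ring carbon. Among the measured compounds shown here, no measured step bears on this change, and every value sits at the limit, so compound 4 is expected to sit at that limit as well, the step that the limit leaves unreadable from compound 1 to compound 4 being expected to carry no readable size. Compound 4 is estimated at 10000 nM, between 3000 nM and 50000 nM.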

Compound 4, half-maximal inhibitory concentration: > 5000 nM
Compound 4: no number, only a limit (the forecaster's own chance of this, stated with the estimate: 80%); the middle value is on the limit's open side.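

In this assay compound 4 gives > 5000 nM, again a limit, so its step from compound 1 cannot be read. The compounds shown leave open which change, if any, would give a readable number in this assay: the limit of > 5000 nM in this assay, at which 4 of the 4 values shown sit.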